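This account rests on a few compounds, and the source may have more. Where it says the series, first, only, none or still open, it means among the compounds named here.

Measured compounds:
compound 1, `COc1ccc(-c2cn3ccnc3c(-c3ccc4ncn(C5CCCCC5)c4c3)n2)cc1`, -43.4% in a functional assay on SF-539 cells (Homo sapiens) for inhibition, read by sulforhodamine B assay, with a stated time of 48 h, tested at 10 uM; on this read-out lower numbers stand for less inhibition and higher numbers for more inhibition at the one concentration tested (going by the name of the read-out)
compound 2, `Clc1ccc(-c2cn3ccnc3c(-c3ccc4ncn(C5CCCCC5)c4c3)n2)cc1`, 6.3%

Among the measured compounds shown here, compound 2 gives the higher of the two numbers, and the only step known, a number 49.7 percentage points higher from compound 1 to compound 2 (beyond the scatter), is the one that separates it from compound 1. Compound 3, `COc1ccccc1-c1cn2ccnc2c(-c2ccc3ncn(C4CCCCC4)c3c2)n1`, is not yet measured. It differs from compound 2 by 2-methoxyphenyl in place of 4-chlorophenyl on an aromatic carbon. For the measured compounds named here, the one step that bears on this change is a number 49.7 percentage points higher from compound 1 to compound 2 (beyond the scatter), where chloro replacing methoxy raised the number; here chloro leaves and a methoxy returns, so a fall is expected, estimated as a number 26.3 percentage points lower from compound 2 to compound 3 (beyond the scatter). Compound 3 is therefore expected to give -20%, within -50% to 15%.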

Compound 3, a percentage reported as inhibition, at one concentration (the size of the read-out at that concentration, not a potency): 8.07%
Compound 3: middle estimate off by 28.1 percentage points, on the low side, within the range that was stated.
By their numbers in this assay, from the lowest: compound 1; then compounds 2 and 3 (each within the scatter of the next).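

In this assay, 2-methoxyphenyl in place of 4-methoxyphenyl brings a number 51.5 percentage points higher from compound 1 to compound 3 (beyond the scatter), so among these compounds a methoxy group does not by itself go with the low number; where it sits on the phenyl ring matters. Meanwhile, 2-methoxyphenyl in place of 4-chlorophenyl gives a number 1.8 percentage points higher from compound 2 to compound 3 (within the scatter), so these two groups are not told apart here. No measurement at hand accounts for the gap between the two methoxyphenyl compounds. 

Left open is how a phenyl ring carrying an amine or a carboxylic acid would read, and whether the position of chloro on the ring matters as that of methoxy does.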